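The compounds below may be only part of what the source reports. "The series", "measured", "known", "first", "only" and "open" are said of these compounds alone.

Measured compounds: compound 1 `Cc1cc2ccccc2nc1-c1cn(-c2ccc(F)cc2)nn1`, compound 2 `CCc1cc2ccccc2nc1-c1cn(-c2ccc(F)cc2)nn1`, compound 3 `CCc1cc2ccccc2nc1-c1cn(CCC(F)(F)C(F)(F)C(F)(F)C(F)(F)C(F)(F)C(F)(F)C(F)(F)C(F)(F)F)nn1`.

In a functional assay on THP-1 cells (Homo sapiens) for cytotoxicity, read by MTT assay, with a stated time of 24 h (on this read-out higher numbers stand for weaker inhibition and lower numbers for stronger inhibition), compound 1 gives > 100 ug/mL, a limit of the assay. Compound 2 gives > 100 ug/mL in this assay, likewise a limit. Compound 3 gives > 100 ug/mL in this assay, again a limit. The step that the two limits leave unreadable from compound 1 to compound 2 is therefore not readable; the change made there is methyl in place of hydrogen on a saturated chain carbon bound to an aromatic carbon. The difference between the core of compound 1 and the core of compound 3 is not broken down here.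

The unmeasured compound 4 `CCCc1cc2ccccc2nc1-c1cn(CCC(F)(F)C(F)(F)C(F)(F)C(F)(F)C(F)(F)C(F)(F)C(F)(F)C(F)(F)F)nn1` differs from compound 3 by methyl in place of hydrogen on a saturated chain carbon, two bonds along the chain from an aromatic carbon. This is the same kind of change as that from compound 1 to compound 2, but the place differs: there the carbon is bound to an aromatic carbon, here it sits two bonds along the chain from an aromatic carbon.

Compound 4 is expected to give 150 ug/mL in this assay, resting on compound 3 at > 100 ug/mL and on (the limit of > 100 ug/mL in this assay, at which 3 of the 3 values shown sit). The expected step is a step that the limit leaves unreadable from compound 3 to compound 4, most likely again only a limit.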

Compound 4, half-maximal inhibitory concentration: > 100 ug/mL
Compound 4: no number, only a limit; the forecaster's own chance of this, stated with the estimate: 85%; the middle value does not contradict the limit.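

No new step can be read: compound 3 and compound 4 both stand only at a limit in this assay. The compounds shown leave open whether any change to this series would give a readable number in this assay.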